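The compounds below may be only part of what the source reports. "The series", "measured", "known", "first", "only" and "open" are said of these compounds alone.

The measured compounds:

Compound 1, `COc1ccc(C(=O)c2ccc(OC)c3c2C=CC(C)(C)O3)c(NC(=O)CO)c1`, gives 940 nM.
Compound 2, `COc1ccc(C(=O)c2ccc(OC)c3c2C=CC(C)(C)O3)c(NC(=O)CN)c1`, gives 1250 nM.
Compound 3, `C=C(c1ccc(OC)cc1NC(=O)CO)c1ccc(OC)c2c1OC(C)(C)C=C2`, gives 100 nM.

All three were tested in a functional assay on MCF7 cells (Homo sapiens) for antiproliferative activity, read by MTT assay, with a stated time of 48 h; a higher number here means a weaker inhibitor, a lower number a stronger inhibitor. Compound 1 and compound 2 share a core and differ in a single place: amino in place of hydroxy on a saturated chain carbon bound to a carbonyl carbon. That change produced a 1.3-fold higher number from compound 1 to compound 2 (0.12 log units; within the scatter), so the two values cannot be ordered against each other. Compound 3 carries a different core; how its core differs from the core of compound 1 is not broken down here. What the numbers show is that compound 3 has the lowest value of the three, and its gap to compound 1 and to compound 2 lies beyond the scatter in each case.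

Compound 4, `C=C(c1ccc(OC)cc1NC(=O)CN)c1ccc(OC)c2c1OC(C)(C)C=C2`, has not yet been measured. It differs from compound 3 in one place: amino in place of hydroxy on a saturated chain carbon bound to a carbonyl carbon. This is the same change that separates compound 2 from compound 1, made at the same kind of position on the same kind of chain. Since that earlier step, a 1.3-fold higher number from compound 1 to compound 2 (0.12 log units; within the scatter), stayed within the scatter, the step from compound 3 to compound 4 is expected to be of similar small size, a 1.3-fold higher number from compound 3 to compound 4 (0.11 log units; within the scatter). On that basis compound 4 is estimated at 130 nM in this assay, with a plausible range from 60 nM to 300 nM.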

Compound 4, half-maximal inhibitory concentration: 220 nM
Estimate against measurement, compound 4: 1.7-fold (0.23 log units) below; measured number inside the range.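

In this assay, putting amino in place of hydroxy on a saturated chain carbon bound to a carbonyl carbon gave a 2.2-fold higher number from compound 3 to compound 4 (0.34 log units; beyond the scatter), a modest step that only just clears the usual scatter. Set beside the earlier step, it cannot be told apart from it: the same change on two cores in this assay, a 1.3-fold higher number (0.12 log units; within the scatter) from compound 1 to compound 2 and a 2.2-fold higher number (0.34 log units; beyond the scatter) from compound 3 to compound 4, 1.7-fold (0.22 log units) apart, within the scatter of two such steps. Among these compounds, the change therefore carried from the core of compound 1 to the core of compound 3 with the number moving the same way on both and with no measurable difference in size, but this rests on only two pairs of compounds, and it neither shows that the step is truly identical on the two cores nor explains why the number moves at all.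

The compounds shown leave open how a dimethylamino group, a carboxylic acid or a longer chain ending in an amine would read in the same place, since only hydroxy and amino are compared there. They also leave open whether the step would hold on any further core, or outside this assay.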